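The compounds below may be only part of what the source reports. "The series", "measured", "known", "first", "only" and "open" are said of these compounds alone.

Measured compounds in a functional assay on cells (Pituitary gland cell) with growth hormone secretagogue receptor type 1 (Rattus norvegicus) as the target; on this read-out higher numbers stand for an effect only at larger amounts of compound and lower numbers for an effect already at smaller amounts:
compound 1 `NCCC(=O)N[C@@H]1CCc2ccccc2N(Cc2ccc(-c3ccccc3-c3nn[nH]n3)cc2)C1=O` gives 2 uM
compound 2 `CC[C@@H](N)C(=O)N[C@@H]1CCc2ccccc2N(Cc2ccc(-c3ccccc3-c3nn[nH]n3)cc2)C1=O` gives 0.3 uM
compound 3 `CC(C)(CC(=O)N[C@@H]1CCc2ccccc2N(Cc2ccc(-c3ccccc3-c3nn[nH]n3)cc2)C1=O)NCCO` gives 30 uM

Compound 3 carries the highest number of the three: a 15-fold higher number from compound 1 to compound 3 (1.18 log units; beyond the scatter) and a 100-fold higher number from compound 2 to compound 3 (2.00 log units; beyond the scatter), both beyond the scatter. Compound 4 `CC(C)(CC(=O)N[C@@H]1CCc2ccccc2N(Cc2ccc(-c3ccccc3-c3nn[nH]n3)cc2)C1=O)NCCN` differs from compound 3 in one place: amino in place of hydroxy on a saturated chain carbon, two bonds along the chain from an amine nitrogen.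

Going by the values given here, no measured step exchanges hydroxy for amino, so none bears directly on this change. The measured steps alter the amine-bearing chain itself, and a 6.7-fold lower number from compound 1 to compound 2 (0.82 log units; beyond the scatter) shows that a small alteration there can move this assay beyond the scatter. Compounds 1 and 2, both with a free amino group on the chain, give lower numbers than compound 3, but they lack the 1-methylethyl branching and the (2-hydroxyethyl)amino group, so the comparison is indirect. The expectation for compound 4 is therefore a modest lowering, a 3.0-fold lower number from compound 3 to compound 4 (0.48 log units; beyond the scatter), with wide uncertainty. Compound 4 is estimated at 10 uM in this assay, in the range 2 uM to 50 uM.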

Compound 4, concentration for half-maximal effect: 230 uM
Beside the measured number, compound 4's estimate is 23-fold (1.36 log units) below it; measured number outside the range, above it.
By their numbers in this assay, from the lowest: compound 2; then compound 1; then compound 3; then compound 4.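

In this assay, amino in place of hydroxy on a saturated chain carbon, two bonds along the chain from an amine nitrogen, gives a 7.7-fold higher number from compound 3 to compound 4 (0.88 log units; beyond the scatter), so this position responds to the change even though the heavy-atom, donor and acceptor counts stay the same. Compound 4 now carries the highest number of the series, with a 770-fold higher number from compound 2 to compound 4 (2.88 log units; beyond the scatter) and a 120-fold higher number from compound 1 to compound 4 (2.06 log units; beyond the scatter), so the free amino groups of compound 1 and compound 2 do not carry over to a low number once amino sits in the (2-aminoethyl)amino group. Nothing shown accounts for the size or direction of this step.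

On these data alone, it remains open how a methoxy or a dimethylamino group in place of hydroxy would read here. As far as these compounds go, a chain longer than 2-aminoethyl on the same amine nitrogen is also open.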